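Methoxy to hydroxy on the aromatic ring of compound 2

The source may hold more compounds than are shown below. What is called first, only, known or untested is meant among the compounds shown, and "the series" means these compounds.

In a functional assay on OVCAR-3 cells (Homo sapiens) for inhibition, read by sulforhodamine B assay, with a stated time of 48 h (a lower number here means a stronger inhibitor of growth, a higher number a weaker inhibitor of growth), compound 2 `COc1ccc(/C=N/NC(=S)NC(C)(C)[C@H]2CC=C(C)CC2)cc1` gives 7900 nM, the lower of the two numbers shown, yet within the scatter of compound 1 `CC1=CC[C@H](C(C)(C)NC(=S)N/N=C/c2ccccc2)CC1`, which gives 8700 nM; the step is a 1.1-fold lower number from compound 1 to compound 2 (0.04 log units; within the scatter). Compound 3 `CC1=CC[C@H](C(C)(C)NC(=S)N/N=C/c2ccc(O)cc2)CC1` differs from compound 2 by hydrogen in place of methyl on an oxygen on an aromatic ring, so 4-methoxyphenyl becomes 4-hydroxyphenyl. For the measured compounds named here, the only measured step that bears on this position is that between compound 1 and compound 2, which stayed within the scatter; no step beyond the scatter in this assay is therefore expected for compound 3. Compound 3 is estimated at 8000 nM, with a range of 4000 nM to 16000 nM. The expected step is a 1.0-fold higher number from compound 2 to compound 3 (0.01 log units; within the scatter).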

Compound 3, concentration for 50% growth inhibition: > 100000 nM
Compound 3: a limit, no number; the forecaster's own chance of this, stated with the estimate: 5%; at least 12-fold (1.09 log units) between middle value and limit.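

Compound 3 reads as a limit in this assay, not as a number: the limit of > 100000 nM in this assay, at which 1 of the 3 values shown sits. This position on the aromatic ring is therefore not indifferent to what it carries: the change from methoxy to hydroxy gives an at least 12-fold higher number from compound 2 to compound 3 (1.10 log units; beyond the scatter), and hydroxy in place of hydrogen gives an at least 11-fold higher number from compound 1 to compound 3 (1.06 log units; beyond the scatter). Methoxy in place of hydrogen, by contrast, stayed within the scatter.

As far as these compounds go, how far compound 3 lies past its limit stays open. Also open, from the compounds shown here alone, is whether an amine or a fluorine on the same aromatic carbon would read like methoxy or like hydroxy.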